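This account rests on a few compounds, and the source may have more. Where it says the series, first, only, none or still open, it means among the compounds named here.

Working notes on the series.

The shared core carries an ester side chain on one face and a variable aryl group on a saturated ring carbon. Compound 1 `CC1=NC(C)=C(C(=O)O)C(c2ccccc2)/C1=C(\O)OC/C=C/c1ccccc1` gives 2000 nM in a functional assay on IMR-32 cells for inhibition of Voltage-dependent N-type calcium channel subunit alpha-1B (Homo sapiens), read by calcium flux; on this read-out higher numbers stand for weaker inhibition and lower numbers for stronger inhibition. Among the measured compounds shown here, compound 2 `CC1=NC(C)=C(C(=O)O)C(c2cccnc2)/C1=C(\O)OC/C=C/c1ccccc1` gives 24000 nM; the step of a 12-fold higher number from compound 1 to compound 2 (1.08 log units; beyond the scatter) is the only single-point comparison so far. Compound 3 `CC1=NC(C)=C(C(=O)O)C(c2cccc(Cl)c2)/C1=C(\O)OC/C=C/c1ccc(Cl)cc1` gives 1500 nM, the lowest of the three numbers: its gap to compound 1 lies within the scatter, while its gap to compound 2 lies beyond it, so nothing of order can be said between compounds 1 and 3.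

Compound 4 `CC1=NC(C)=C(C(=O)O)C(c2cccc(Cl)c2)/C1=C(\O)OCc1ccc2ccccc2c1` differs from compound 3 in one place: naphthalen-2-yl in place of 2-(4-chlorophenyl)ethenyl on a saturated chain carbon bound to an oxygen on an unsaturated carbon. For the measured compounds named here, no measured step touches this part of the molecule; the one step on record, from compound 1 to compound 2, concerns the aryl group on the ring carbon and is of no direct use here. Compounds 1 and 3 differ in two places and do not isolate the side-chain change either. With no guide from the data, the expected step of a 1.7-fold higher number from compound 3 to compound 4 (0.22 log units; within the scatter) is small and may fall within the scatter. Compound 4 is therefore estimated at 2500 nM in this assay, within a range of 700 nM to 9000 nM.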

Compound 4, half-maximal inhibitory concentration: 1000 nM
Estimate against measurement, compound 4: 2.5-fold (0.40 log units) above, within the range that was stated.
By their numbers in this assay, from the lowest: compounds 4, 3 and 1 (each within the scatter of the next); then compound 2.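

In this assay, among the compounds shown here, the one change read at this position, naphthalen-2-yl in place of 2-(4-chlorophenyl)ethenyl on a saturated chain carbon bound to an oxygen on an unsaturated carbon, gives a 1.5-fold lower number from compound 3 to compound 4 (0.18 log units; within the scatter) and so leaves the two groups indistinguishable on this read-out. For the compounds shown here, with the aryl group on the ring carbon held as in compound 3, a group with one six-membered aromatic ring and a double bond outside aromatic rings gives way to one with 2 such rings and no such double bond, with no step beyond the scatter, while the only step beyond it, a 12-fold higher number from compound 1 to compound 2 (1.08 log units; beyond the scatter), stands at the aryl group on the ring carbon. No evidence at hand bears on this result.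

Going by these compounds, the side-chain change is read against a single aryl group on the ring carbon, so whether it stays within the scatter with phenyl or pyridin-3-yl there remains open. Also open, on these data alone, is how this position responds to groups of another kind, such as an amine, a carboxylic acid or a longer chain carrying naphthalen-2-yl.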